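Paw edema series: nitrooxy in place of bromo on acyl chain

This account rests on a few compounds, and the source may have more. Where it says the series, first, only, none or still open, it means among the compounds named here.

Measured so far:
compound 1 `COc1ccc(C2=NN(C(=O)CO[N+](=O)[O-])C(c3ccco3)C2)cc1OC` gives 43% in a functional assay on the whole organism (strain albino) for inhibition, with Rattus norvegicus as the target, read by paw edema, with stated times of 30 min and 3 h, at a dose of 100 mg/kg by the oral route; a lower number here means less inhibition, a higher number more inhibition at the dose given (going by the name of the read-out)
compound 2 `COc1ccc(C2=NN(C(=O)C(C)Br)C(c3ccco3)C2)cc1OC` gives 42% in this assay

Compound 2 stands lowest of the two numbers in this assay, with compound 1 the nearest, the gap being within the scatter. Going by the values given here, the one measured step, a number 1 percentage points lower from compound 1 to compound 2 (within the scatter), exchanged the whole group on the carbonyl carbon and moved nothing beyond the scatter.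

Compound 3 `COc1ccc(C2=NN(C(=O)C(C)O[N+](=O)[O-])C(c3ccco3)C2)cc1OC` is not yet measured. Its change from compound 2 is nitrooxy in place of bromo on a saturated chain carbon bound to a carbonyl carbon and a saturated chain carbon. The step of a number 1 percentage points lower from compound 1 to compound 2 (within the scatter) bears on this, as it covered a larger exchange at the same carbonyl with no effect beyond the scatter; compound 3 also carries the nitrooxy group that compound 1 carries. No step beyond the scatter is therefore expected in this assay, the expected step being a number 1 percentage points higher from compound 2 to compound 3 (within the scatter). Compound 3 is estimated at 43%, within 30% to 56%.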

Compound 3, a percentage reported as inhibition, in the whole organism at one dose (the size of the read-out at that dose, not a potency): 42%
For compound 3 the middle estimate is 1 percentage points above the measured one; low and high end bracket the measured number.
By their numbers in this assay, from the lowest: compounds 2, 3 and 1 (each within the scatter of the next).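

In this assay, nitrooxy in place of bromo on a saturated chain carbon bound to a carbonyl carbon and a saturated chain carbon gives no change at the digits printed from compound 2 to compound 3 (within the scatter), so this exchange, made on its own with the methyl kept, shows no effect beyond the scatter. Methyl in place of hydrogen on a saturated chain carbon bound to a carbonyl carbon and an oxygen on an unsaturated carbon gives a number 1 percentage points lower from compound 1 to compound 3 (within the scatter), so with nitrooxy kept, this methyl also shows no effect beyond the scatter. No measurement on hand accounts for these flat results.

Still open, on these data alone, is whether an amine or a carboxylic acid on this saturated chain carbon, or a longer chain in place of the methyl, would give a step beyond the scatter. The compounds shown also leave open whether these three would stay within the scatter of one another at another oral dose.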